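This account rests on a few compounds, and the source may have more. Where it says the series, first, only, none or still open, it means among the compounds named here.

In a functional assay on HCC827 cells (Homo sapiens) for antiproliferative activity, read by MTT assay, with a stated time of 72 h (on this read-out lower numbers stand for stronger inhibition and higher numbers for weaker inhibition), compound 1 (`CN1CCN(c2ccc(Nc3ncc4nc(Sc5ccccc5)n(C5CCOCC5)c4n3)cc2)CC1`) gives 42.6 nM, compound 2 (`CN(C)C1CCN(c2ccc(Nc3ncc4nc([S+]([O-])c5ccccc5)n(C5CCOCC5)c4n3)cc2)CC1`) gives 1290 nM, and compound 3 (`CN(C)CCN(C)c1ccc(Nc2ncc3nc(Sc4ccccc4)n(C4CCOCC4)c3n2)cc1`) gives 499 nM, the second highest of the three numbers. Compound 4 (`CN(C)C1CCN(c2ccc(Nc3ncc4nc(Sc5ccccc5)n(C5CCOCC5)c4n3)cc2)CC1`) differs from compound 3 in one place: 4-(dimethylamino)piperidin-1-yl in place of (2-(dimethylamino)ethyl)(methyl)amino on an aromatic carbon, with 4-(dimethylamino)piperidin-1-yl in place of (2-(dimethylamino)ethyl)(methyl)amino on an aromatic carbon. Within the data shown here, the only measured step at this place is a 12-fold higher number from compound 1 to compound 3 (1.07 log units; beyond the scatter), where 4-methylpiperazin-1-yl gives way to the open chain, so a ring returning there is expected to recover most of that size in this assay, toward lower numbers. Compound 2 carries the same entering group but differs from compound 4 elsewhere, so it gives no clean comparison. The expected step is a 5.5-fold lower number from compound 3 to compound 4 (0.74 log units; beyond the scatter). Compound 4 is estimated at 90 nM, with a range from 30 nM to 270 nM.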

Compound 4, half-maximal inhibitory concentration: 29.4 nM
Compound 4: the middle estimate sits 3.1-fold (0.49 log units) above what was measured, and the stated range ends above it.
By their numbers in this assay, from the lowest: compounds 4 and 1 (each within the scatter of the next); then compound 3; then compound 2.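

Replacing the open chain with 4-(dimethylamino)piperidin-1-yl gives a 17-fold lower number from compound 3 to compound 4 (1.23 log units; beyond the scatter), while exchanging 4-methylpiperazin-1-yl for the same group gives a 1.4-fold lower number from compound 1 to compound 4 (0.16 log units; within the scatter), so the two six-membered rings cannot be told apart here and the open chain stands apart from both. With 4-(dimethylamino)piperidin-1-yl held constant, the sulfur-linked phenyl group without its oxygen gives a 44-fold lower number from compound 2 to compound 4 (1.64 log units; beyond the scatter), showing that the second place also matters. Nothing given here explains either step. The compounds shown leave open whether a morpholine ring on the aromatic carbon would match these two rings. They also leave open how a sulfone or an ether link would compare at the second place.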